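Dropping One Chlorine from a Pyrazolone

The source may hold more compounds than are shown below. What is called first, only, known or untested is meant among the compounds shown, and "the series" means these compounds.

Of the compounds shown here, two have been measured so far. In an assay on isolated protein for inhibition of alpha-ketoglutarate-dependent dioxygenase alkB homolog 3 (Homo sapiens), read by polymerase chain reaction, with a stated time of 1 h, tested at 10 mM (on this read-out lower numbers stand for less inhibition and higher numbers for more inhibition at the one concentration tested (going by the name of the read-out)), compound 1 `Cc1[nH]n(-c2ncccn2)c(=O)c1C` gives -4%, while compound 2 `Cc1[nH]n(-c2nc3ccccc3[nH]2)c(=O)c1Cc1ccc(Cl)cc1Cl` gives 11%, the higher of the two numbers, a gap that lies beyond the usual scatter. Compound 3 `Cc1[nH]n(-c2nc3ccccc3[nH]2)c(=O)c1Cc1ccccc1Cl` is made from compound 2 by one change: hydrogen in place of chloro on an aromatic carbon. Since both measured numbers sit near no inhibition, only a small step is expected in this assay, downward or none beyond the scatter: a number 6 percentage points lower from compound 2 to compound 3 (within the scatter). Compound 3 is therefore expected to give 5%, with a range from -10% to 20%.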

Compound 3, a percentage reported as inhibition, at one concentration (the size of the read-out at that concentration, not a potency): -13%
Beside the measured number, compound 3's estimate is 18 percentage points above it, and the stated range ends above it.
By their numbers in this assay, from the lowest: compounds 3 and 1 (each within the scatter of the next); then compound 2.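

In this assay, going by these compounds alone, the change from 2,4-dichlorophenyl to 2-chlorophenyl gives a number 24 percentage points lower from compound 2 to compound 3 (beyond the scatter), the first comparison here between compounds that differ in one place. It shows that this single chloro, para to a large group, makes a measurable difference, although the step is modest and all the numbers remain small.

From the compounds shown here alone, whether a fluoro, a methoxy or an amine in the same place would match the chloro remains open. Why the number falls also remains unexplained, since no supporting measurement bears on it.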